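Swapping the aryl group on the hydrazone carbon: compound 4

A few compounds are considered here, and "the series" means these few. Any claim that something is new, unique, unknown or untested is made for them only; others in the source may bear on it.

Measured so far:
- Compound 1, `CN(C)CCn1cnnc1-c1cc(Oc2ccc(NC(=O)N/N=C/c3ccc(F)cc3Cl)cc2F)ccn1`: 1210 nM
- Compound 2, `CN(C)CCn1cnnc1-c1cc(Oc2ccc(NC(=O)N/N=C/c3cccc(Cl)c3Cl)cc2F)ccn1`: 13200 nM
- Compound 3, `COc1ccc(/C=N/NC(=O)Nc2ccc(Oc3ccnc(-c4nncn4CCN(C)C)c3)c(F)c2)c(OC)c1`: 12600 nM

These three compounds share one core and differ only in the aryl group on a carbon with a double bond to nitrogen. In a functional assay on U-87MG ATCC cells (Homo sapiens) for cytotoxicity, read by MTT assay, with a stated time of 72 h (a higher number here means a weaker inhibitor, a lower number a stronger inhibitor), compound 1 gives 1210 nM. Compound 2 and compound 3 sit far from it: the step of an 11-fold higher number from compound 1 to compound 2 (1.04 log units; beyond the scatter) and the step of a 10-fold higher number from compound 1 to compound 3 (1.02 log units; beyond the scatter) are both large, while between compound 2 and compound 3 the step of a 1.0-fold lower number from compound 2 to compound 3 (0.02 log units; within the scatter) is within the scatter. Compound 3 thus stands near the top of the three numbers, alongside compound 2, and far from compound 1.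

Compound 4, `COc1cc(/C=N/NC(=O)Nc2ccc(Oc3ccnc(-c4nncn4CCN(C)C)c3)c(F)c2)cc(OC)c1OC`, has not yet been tested in this assay. Its change from compound 3 is 3,4,5-trimethoxyphenyl in place of 2,4-dimethoxyphenyl on a carbon with a double bond to nitrogen. Going by the values given here, no measured step adds or moves methoxy groups, so nothing here speaks directly to this change. Among the compounds with values here, the only step that reaches compound 3, a 1.0-fold lower number from compound 2 to compound 3 (0.02 log units; within the scatter), was within the scatter, and the two larger steps both concern the move away from compound 1. With no sign pointing either way, compound 4 is expected to stay close to compound 3, with an expected step of a 1.1-fold lower number from compound 3 to compound 4 (0.02 log units; within the scatter) that lies within the scatter. Compound 4 is estimated at 12000 nM, likely between 4000 nM and 40000 nM.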

Compound 4, half-maximal inhibitory concentration: 22500 nM
Compound 4: middle estimate off by 1.9-fold (0.27 log units), on the low side, within the range that was stated.
By their numbers in this assay, from the lowest: compound 1; then compounds 3, 2 and 4 (each within the scatter of the next).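

In this assay, compound 4 does not separate from compound 2 or compound 3: both steps (a 1.8-fold higher number from compound 3 to compound 4 (0.25 log units; within the scatter) and a 1.7-fold higher number from compound 2 to compound 4 (0.23 log units; within the scatter)) lie within the scatter, so these three values cannot be put in order. The earlier compounds shown here showed that 2,3-dichlorophenyl and 2,4-dimethoxyphenyl on this carbon gave matching numbers, and 3,4,5-trimethoxyphenyl now joins them, so a third aryl group, larger than 2,4-dimethoxyphenyl by one more methoxy group, gives no clear change. The large step to the trimethoxy compound (a 19-fold higher number from compound 1 to compound 4 (1.27 log units; beyond the scatter)) leaves 2-chloro-4-fluorophenyl as the only aryl group among these four that stands apart, with the lowest number, and no measurement at hand explains why this position behaves this way.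

The compounds shown leave open whether the chlorine or the fluorine of that group matters more, since both always appear together in compound 1. They also leave open how an aryl ring carrying an amine or a carboxylic acid would behave on this carbon.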